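Series notes: pyridin-3-yl in place of the aryl hydrazone

This account rests on a few compounds, and the source may have more. Where it says the series, first, only, none or still open, it means among the compounds named here.

Among the compounds with values here, compound 3 `COc1cccc(/C=N/NC(=O)c2cccnc2Nc2cccc(C(F)(F)F)c2)c1` gives 52.8% in a functional assay on the whole organism (strain Wistar) for inhibition, with Rattus norvegicus as the target, read by paw edema, with a stated time of 30 min, at a dose of 10 mg/kg by the intraperitoneal route (on this read-out lower numbers stand for less inhibition and higher numbers for more inhibition at the one dose given (going by the name of the read-out)), the lowest of the three numbers so far. Compound 1 `O=C(N/N=C/c1cccc(F)c1)c1cccnc1Nc1cccc(C(F)(F)F)c1` gives 58.3% in this assay; compound 2 `O=C(N/N=C/c1cccc(Cl)c1)c1cccnc1Nc1cccc(C(F)(F)F)c1` gives 77.8%. Against compound 3 the measured steps are a number 25 percentage points lower from compound 2 to compound 3 (beyond the scatter) and a number 5.5 percentage points lower from compound 1 to compound 3 (within the scatter); the one rise seen is a number 19.5 percentage points higher from compound 1 to compound 2 (beyond the scatter). Compound 4 `O=C(N/N=C/c1cccnc1)c1cccnc1Nc1cccc(C(F)(F)F)c1` differs from compound 3 as follows: pyridin-3-yl in place of 3-methoxyphenyl on a carbon with a double bond to nitrogen. Every measured step swaps one substituent for another on the same ring; none exchanges the ring itself, so none bears directly on this change. Without a precedent, the step is expected to be a number 0.8 percentage points lower from compound 3 to compound 4 (within the scatter), nothing beyond the scatter. Compound 4 is therefore expected to give about 52%, within 35% to 70%.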

Compound 4, a percentage reported as inhibition, in the whole organism at one dose (the size of the read-out at that dose, not a potency): 59.1%
The estimate for compound 4 lay 7.1 percentage points below the measured number, and the stated range covers the measured number.
By their numbers in this assay, from the lowest: compounds 3, 1 and 4 (each within the scatter of the next); then compound 2.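

On the carbon with a double bond to nitrogen, the aromatic ring itself can be exchanged without a step beyond the scatter in this assay: pyridin-3-yl for 3-methoxyphenyl gives a number 6.3 percentage points higher from compound 3 to compound 4 (within the scatter) and pyridin-3-yl for 3-fluorophenyl gives a number 0.8 percentage points higher from compound 1 to compound 4 (within the scatter) here. The 3-chlorophenyl group remains apart from this group of compounds, with a number 18.7 percentage points lower from compound 2 to compound 4 (beyond the scatter) on the same exchange. No measurement at hand accounts for these steps. Open, as far as these compounds go, is whether a piperidine ring at this carbon, or a phenyl ring carrying an amine or a carboxylic acid, stays within this range. Also open, from the compounds shown here alone, is whether the gap to the 3-chlorophenyl compound holds at other doses.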